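The source may hold more compounds than are shown below. What is called first, only, known or untested is meant among the compounds shown, and "the series" means these compounds.

Compound 1 `Cc1ccccc1NC(=O)N[C@H](C)c1ccccc1` and compound 2 `Cc1ccccc1NC(=O)N[C@@H](C)c1ccccc1` share all atoms and bonds. In an ADME assay on the whole organism with Oryza sativa as the target, tested at 10 uM (on this read-out higher numbers stand for a weaker effect at the one concentration tested and lower numbers for a stronger effect), compound 1 gives 99%; compound 2 gives 99%. The step of no change at the digits printed from compound 1 to compound 2 (within the scatter) sits alongside (the fact that compounds 1 and 2 differ only in the configuration as drawn). Compound 3 `CC(C)c1ccc(NC(=O)N[C@H](C)c2ccccc2)cc1` gives 49%, so compound 1 stands with compound 2 at the higher end of the three numbers, well above compound 3.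

Compound 4 `C[C@@H](NC(=O)Nc1ccccc1C(F)(F)F)c1ccccc1` is not yet measured. Against compound 1 the change is trifluoromethyl in place of methyl on an aromatic carbon. Among the compounds with values here, the only measured step, from compound 1 to compound 2, touches configuration alone and gave no change, so no measured step speaks to a substituent swap on the aromatic carbon. The expected step is therefore a number 11 percentage points lower from compound 1 to compound 4 (beyond the scatter), small and downward if any. Compound 4 is expected at 88%, within 55% to 100%.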

Compound 4, a percentage reported as activity, at one concentration (the size of the read-out at that concentration, not a potency): 54%
Compound 4: the middle estimate sits 34 percentage points above what was measured; measured number outside the range, below it.
By their numbers in this assay, from the lowest: compounds 3 and 4 (each within the scatter of the next); then compounds 1 and 2 (each within the scatter of the next).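

Trifluoromethyl in place of methyl on an aromatic carbon, ortho to a large group, gives a number 45 percentage points lower from compound 1 to compound 4 (beyond the scatter) in this assay, a stronger effect at the one concentration tested. The number at this position therefore depends on the substituent, which the configuration pair alone could not show. Nothing measured in the series gives a cause for this step.

From the compounds shown here alone, whether a chlorine atom, a methoxy group or a nitrile at this position gives a similar number stays open. So does whether the opposite configuration of compound 4 matches it, as it does for the methyl pair.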